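The compounds below may be only part of what the source reports. "The series", "measured", "known", "first", "only" and "open" are said of these compounds alone.

The measured compounds:
compound 1 `COc1cccc([C@@H]2OC[C@H]([C@@H](O)c3ccc(OC)c(OC)c3)C[C@H]2C/C=C/c2ccc(OC)c(OC)c2)c1` gives 30100 nM in a functional assay on HeLa cells (Homo sapiens) for cytotoxicity, read by WST assay, with a stated time of 48 h; on this read-out higher numbers stand for weaker inhibition and lower numbers for stronger inhibition;
compound 2 `COc1ccc(/C=C/C[C@H]2C[C@@H]([C@@H](O)c3ccccc3)CO[C@@H]2c2ccccc2)cc1` gives 8300 nM in this assay;
compound 3 `COc1ccc([C@H](O)[C@H]2CO[C@@H](c3ccc(OC)c(OC)c3)[C@H](C/C=C/c3ccc(OC)c(OC)c3)C2)cc1` gives 32200 nM in this assay.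

Among these three, compound 2 carries the lowest number, and its gaps to compound 1 and to compound 3 both lie beyond the scatter of repeated runs. Compound 4 `O[C@@H](c1ccccc1)[C@H]1CO[C@H](c2ccccc2)[C@@H](C/C=C/c2ccccc2F)C1` has not been measured; it differs from compound 2 in a single place: 2-fluorophenyl in place of 4-methoxyphenyl on a double-bonded chain carbon bound to a double-bonded chain carbon. For the measured compounds named here, no measured pair shows this change, so nothing in these data fixes its size. In this assay the step is expected to be small, within or only just beyond the scatter, with a slight lean toward a higher number, as a 1.3-fold higher number from compound 2 to compound 4 (0.12 log units; within the scatter). Compound 4 is estimated at 11000 nM, in the range 4000 nM to 30000 nM.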

Compound 4, half-maximal inhibitory concentration: 9730 nM
Compound 4: the middle estimate sits 1.1-fold (0.05 log units) above what was measured, within the range that was stated.
By their numbers in this assay, from the lowest: compounds 2 and 4 (each within the scatter of the next); then compounds 1 and 3 (each within the scatter of the next).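

With 2-fluorophenyl in place of 4-methoxyphenyl on a double-bonded chain carbon bound to a double-bonded chain carbon, this assay gives a 1.2-fold higher number from compound 2 to compound 4 (0.07 log units; within the scatter), so the two groups cannot be told apart on this read-out. For the compounds shown here, this is the only measured step at this position, and it shows that the position can carry a fluorine-bearing phenyl instead of a methoxy-bearing one with no difference beyond the scatter. Nothing available explains this result. Going by these compounds, whether an unsubstituted phenyl, an amine or a carboxylic acid at this position would read the same stays open.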